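A few compounds are considered here, and "the series" means these few. Any claim that something is new, unique, unknown or untested is made for them only; others in the source may bear on it.

Two compounds of this series carry a measured value. Compound 1 `O=C(NNc1ccccc1Cl)c1ccc(NS(=O)(=O)c2cnc(O)nc2O)cc1` was tested in a functional assay on SGC-7901 cells (Homo sapiens) for antiproliferative activity, read by MTT assay, with a stated time of 24 h (a higher number here means a weaker inhibitor, a lower number a stronger inhibitor), where compound 1 gives 3630 nM. Compound 2 `CCCCOc1ccc(C(=O)NNC(=O)c2ccc(NS(=O)(=O)c3cnc(O)nc3O)cc2)cc1` differs from it in more than one place, and in this assay compound 2 gives 14700 nM, the highest of the two numbers, with compound 1 as its nearest neighbour at a gap beyond the usual scatter. Compound 3 `O=C(NNC(=O)c1ccccc1Cl)c1ccc(NS(=O)(=O)c2cnc(O)nc2O)cc1`, not yet measured, is reached from compound 2 by one change: 2-chlorophenyl in place of 4-butoxyphenyl on a carbonyl carbon. For the measured compounds named here, the group that enters is the same 2-chlorophenyl that compound 1 carries, though there it sits elsewhere, so no direct precedent for this step exists. On that basis a moderate fall in the number is expected for compound 3, of about a 2.5-fold lower number from compound 2 to compound 3 (0.39 log units; beyond the scatter), with the estimate for compound 3 placed at 6000 nM, within a range from 2000 nM to 18000 nM.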

Compound 3, half-maximal inhibitory concentration: 3240 nM
Beside the measured number, compound 3's estimate is 1.9-fold (0.27 log units) above it; measured number inside the range.
By their numbers in this assay, from the lowest: compounds 3 and 1 (each within the scatter of the next); then compound 2.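

In this assay, for the compounds shown here, 2-chlorophenyl in place of 4-butoxyphenyl on a carbonyl carbon gives a 4.5-fold lower number from compound 2 to compound 3 (0.66 log units; beyond the scatter), the first reading of a single change at this position, and it shows that the number depends on the group held there. Compound 3 also links to compound 1: (2-chlorophenyl)carbonyl in place of 2-chlorophenyl on an amine nitrogen gives a 1.1-fold lower number from compound 1 to compound 3 (0.05 log units; within the scatter), so with the 2-chlorophenyl group kept, the added carbonyl leaves the two compounds within the scatter. Nothing in the data given accounts for either step.

The step from compound 2 to compound 3 exchanges a whole substituted ring, so it does not separate the loss of the butoxy chain from the gain of the chlorine. As far as these compounds go, how a plain phenyl group, or a methoxy group or an amine on that ring, would read at this position remains open.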